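The source may report more compounds than this note shows. Statements on the series, on what has been measured and on what is new or still open speak of the compounds shown alone.

Compounds measured so far:
compound 1 `Cc1ccccc1N(C)C(=O)c1ccc(-c2ccc(OS(N)(=O)=O)c(Cl)c2)o1` gives 25 nM in an assay on T47D cells for inhibition of Steryl-sulfatase (Homo sapiens), read by HPLC, with a stated time of 24 h; a higher number here means a weaker inhibitor, a lower number a stronger inhibitor;
compound 2 `Cc1cc(-c2ccc(C(=O)N(C)c3ccccc3C)o2)ccc1OS(N)(=O)=O` gives 570 nM.

Compound 2 stands highest of the two numbers, its nearest neighbour being compound 1 at a 23-fold higher number from compound 1 to compound 2 (1.36 log units; beyond the scatter). Compound 3 `Cc1ccccc1N(C)C(=O)c1ccc(-c2ccc(OS(N)(=O)=O)c(F)c2)o1` differs from compound 2 by fluoro in place of methyl on an aromatic carbon. Among the compounds with values here, the one measured step that bears on this exchange is a 23-fold higher number from compound 1 to compound 2 (1.36 log units; beyond the scatter), where a halogen was replaced by methyl and the number rose sharply; putting a halogen back is expected to reverse much of that. Compound 3 is therefore expected to give 40 nM, within 12 nM to 150 nM. That estimate means an expected step of a 14-fold lower number from compound 2 to compound 3 (1.15 log units; beyond the scatter).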

Compound 3, half-maximal inhibitory concentration: 17 nM
Estimate against measurement, compound 3: 2.4-fold (0.37 log units) above, within the range that was stated.
By their numbers in this assay, from the lowest: compounds 3 and 1 (each within the scatter of the next); then compound 2.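

In this assay the step from methyl to fluoro, ortho to a sulfamoyloxy group, is a 34-fold lower number from compound 2 to compound 3 (1.53 log units; beyond the scatter), so the low number at this position is not confined to chloro. The two halogens cannot be told apart here, with a 1.5-fold lower number from compound 1 to compound 3 (0.17 log units; within the scatter). Nothing available explains why methyl stands apart from both halogens. The compounds shown leave open how bromo, methoxy or a nitrile would read at this position. They also leave open where a plain hydrogen there would fall relative to the halogens and methyl.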